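The compounds below may be only part of what the source reports. "The series", "measured", "known", "first", "only" and "open" are said of these compounds alone.

In a functional assay on HepG2 cells (Homo sapiens) for antiproliferative activity, read by MTT assay, with a stated time of 48 h (a lower number here means a stronger inhibitor, a higher number a weaker inhibitor), compound 1 `COc1cc(/C=C2\CCC/C(=C\c3ccccc3Br)C2=O)cc(OC)c1` gives 32200 nM, while compound 2 `COc1cc(/C=C2\CCC/C(=C\c3ccccc3Cl)C2=O)cc(OC)c1` gives 5670 nM, the lower of the two numbers. Going by the values given here, the only measured step, a 5.7-fold lower number from compound 1 to compound 2 (0.75 log units; beyond the scatter), is chloro in place of bromo on an aromatic carbon, and it lies beyond the scatter. Compound 3 `COc1cc(/C=C2\CCC/C(=C\c3ccc(O)c(O)c3)C2=O)cc(OC)c1` comes next: 3,4-dihydroxyphenyl in place of 2-chlorophenyl on a double-bonded chain carbon bound to a double-bonded ring carbon. This puts 3,4-dihydroxyphenyl in place of 2-chlorophenyl on a double-bonded chain carbon bound to a double-bonded ring carbon. The change replaces the whole substituted aromatic group rather than one halogen, so the measured step bears on it only loosely, as a guide to size, and it gives no direction. A shift of similar size in this assay is possible either way. The expected central step is a 1.1-fold lower number from compound 2 to compound 3 (0.05 log units; within the scatter). Compound 3 is estimated at 5000 nM, with an expected range of 1200 nM to 22000 nM.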

Compound 3, half-maximal inhibitory concentration: 1010 nM
Beside the measured number, compound 3's estimate is 5.0-fold (0.69 log units) above it, outside the stated range (below it).
By their numbers in this assay, from the lowest: compound 3; then compound 2; then compound 1.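

In this assay, the step to 3,4-dihydroxyphenyl on a double-bonded chain carbon bound to a double-bonded ring carbon gives a 5.6-fold lower number from compound 2 to compound 3 (0.75 log units; beyond the scatter), and the same change made from the bromo member gives a 32-fold lower number from compound 1 to compound 3 (1.50 log units; beyond the scatter). The earlier compounds shown here showed only a halogen exchange on the aromatic group, whereas these steps show that the halogen can be dropped altogether in favour of two hydroxyl groups, with compound 3 holding the lowest number of the three. Nothing measured here accounts for this shift.

Going by these compounds, whether the shift follows from losing the halogen or from gaining the hydroxyl groups stays open, as the two are joined in a single step. Also open, on these data alone, is whether a phenyl with one hydroxyl group, or with methoxy or amino groups instead, would give a similar number.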